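The source may hold more compounds than are shown below. What is called first, only, known or untested is meant among the compounds shown, and "the series" means these compounds.

In a functional assay on SK-BR-3 cells (Homo sapiens) for antiproliferative activity (a higher number here means a weaker inhibitor, a lower number a stronger inhibitor), two compounds with a shared core have been measured so far. Compound 1 `CCCN(CCC)CCCOc1ccc2cc(NC(=O)c3ccc(O)c(CC=C(C)C)c3)c(=O)oc2c1C` gives > 50000 nM, which is a limit of the assay and not a number. Among the compounds with values here, compound 2 `CC(C)=CCc1cc(C(=O)Nc2cc3ccc(OCCCN(C)C(C)C)c(C)c3oc2=O)ccc1O` gives 570 nM, the only actual number available. Within the data shown here, the one measured step is an at least 87-fold lower number from compound 1 to compound 2 (1.94 log units; beyond the scatter). From the compounds shown here alone, it is large, but it starts from the limit of > 50000 nM in this assay, at which 1 of the 2 values shown sits, so its full size remains open.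

Compound 3 `CC(C)=CCc1cc(C(=O)Nc2cc3ccc(OCCCNC(C)(C)C)c(C)c3oc2=O)ccc1O` has not yet been measured. It keeps the core of compound 2 and alters the amine at the end of the same chain: (tert-butyl)amino in place of isopropyl(methyl)amino on a saturated chain carbon, three bonds along the chain from an oxygen on an aromatic ring. Among the measured compounds shown here, the large step at this place shows that a change here can matter greatly in this assay, but no measured compound carries a (tert-butyl)amino group. The guide is therefore compound 2 at 570 nM, with a wide margin on either side. A moderate move towards a higher number is expected, a 2.6-fold higher number from compound 2 to compound 3 (0.42 log units; beyond the scatter). For compound 3 the estimated value is 1500 nM, with an expected range from 300 nM to 10000 nM.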

Compound 3, half-maximal inhibitory concentration: 660 nM
Estimate against measurement, compound 3: 2.3-fold (0.36 log units) above, within the range that was stated.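

In this assay, the exchange of isopropyl(methyl)amino for (tert-butyl)amino gives a 1.2-fold higher number from compound 2 to compound 3 (0.06 log units; within the scatter) and so shows that two amines with the same heavy atoms joined differently, one with a hydrogen-bond donor and one without, cannot be told apart at this position. The new result also gives an at least 75-fold lower number from compound 1 to compound 3 (1.87 log units; beyond the scatter) and so the large change at this place no longer rests on isopropyl(methyl)amino alone, since two different amines now stand apart from dipropylamino. Compound 1 is a limit of the assay and not a number, which leaves the full size of both large steps open: the limit of > 50000 nM in this assay, at which 1 of the 3 values shown sits.

The compounds shown do not tell whether a smaller amine such as dimethylamino, a ring amine such as piperidine or a longer chain between the oxygen and the nitrogen would stay with compound 2 and compound 3 or fall towards compound 1. Nor do they show whether a single propyl group, as in propylamino, would be enough to produce the large step seen with dipropylamino.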